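From Hydroxy to Fluoro on the Aromatic Ring

The compounds below may be only part of what the source reports. "The series", "measured", "known", "first", "only" and "open" are said of these compounds alone.

Measured so far in a physicochemical assay for lipophilicity, using the shake flask method, measured as octanol-water partition, at pH 7.4; on this read-out higher numbers stand for higher lipophilicity and lower numbers for lower lipophilicity
Compound 1 `O=C(CC1SCCNC1=O)Nc1ccccc1` gives 0.8
Compound 2 `O=C(CC1SCCNC1=O)Nc1ccc(O)cc1` gives 0.1

Compound 2 stands at 0.1 and is the lower of the two, with compound 1 nearest. Compound 3 `O=C(CC1SCCNC1=O)Nc1ccc(F)cc1` differs from it as fluoro in place of hydroxy on an aromatic carbon shows, with fluoro in place of hydroxy on an aromatic carbon, para to a large group. Going by the values given here, one measured step bears on this, modest and beyond the scatter, where hydroxy replaced hydrogen. Given a number 0.70 log units lower from compound 1 to compound 2 (beyond the scatter) on that replacement, losing the hydroxy of compound 2 is expected to bring a modest rise of similar size in this assay, although fluoro itself remains unmeasured. The expected step is a number 0.90 log units higher from compound 2 to compound 3 (beyond the scatter) in all. Compound 3 is estimated at 1 with 0.7 to 1.3 as its range.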

Compound 3, distribution coefficient: 1.2
Beside the measured number, compound 3's estimate is 0.20 log units below it; the measured number falls inside the stated range.
By their numbers in this assay, from the lowest: compound 2; then compound 1; then compound 3.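

In this assay, on an aromatic carbon para to a large group, fluoro in place of hydroxy gives a number 1.10 log units higher from compound 2 to compound 3 (beyond the scatter), a large step, while fluoro in place of hydrogen gives a number 0.40 log units higher from compound 1 to compound 3 (beyond the scatter), a modest one. Fluoro therefore does not simply return the number to the level of the unsubstituted compound 1 but passes it. Nothing available accounts for the size of either step. The compounds shown leave open where a chloro, a methoxy or an amine would fall at this place, and whether fluoro elsewhere on the ring would give a similar rise.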